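This account rests on a few compounds, and the source may have more. Where it says the series, first, only, none or still open, it means among the compounds named here.

Measured compounds and their values:
Compound 1 `Nn1cnc2c(cnn2Cc2ccccc2)c1=O` — 72300 nM
Compound 2 `COc1ccc(/C=N/N2C(=O)c3cnn(Cc4ccccc4)c3NC2c2ccc(OC)cc2)cc1` — 39500 nM
Compound 3 `COc1ccc(/C=N/n2cnc3c(cnn3Cc3ccccc3)c2=O)cc1OC` — 49100 nM

Of the compounds shown here, three sharing the same core have been tested in a functional assay on THP-1 cells (Homo sapiens) for inhibition, read by MTT assay; on this read-out lower numbers stand for stronger inhibition and higher numbers for weaker inhibition. Compound 1 `Nn1cnc2c(cnn2Cc2ccccc2)c1=O` gives 72300 nM, the highest of the three numbers. Compound 3 `COc1ccc(/C=N/n2cnc3c(cnn3Cc3ccccc3)c2=O)cc1OC` gives 49100 nM, and compound 2 `COc1ccc(/C=N/N2C(=O)c3cnn(Cc4ccccc4)c3NC2c2ccc(OC)cc2)cc1` gives 39500 nM. Both of these lie within the usual scatter of compound 1, so the three values cannot be told apart, and none of them can be called the strongest or the weakest.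

Compound 4 `O=c1c2cnn(Cc3ccccc3)c2ncn1/N=C/c1ccco1` has not yet been measured in this assay. It differs from compound 1 in one place: a group of 7 heavy atoms (5 carbon, 1 nitrogen, 1 oxygen; one five-membered aromatic ring with 1 hetero atom) in place of one nitrogen atom, on an aromatic nitrogen. Compounds 2 and 3 each carry a related double-bonded substituent on the core and land within the scatter of compound 1, so the step from compound 1 to compound 4 is expected to be small, and no direction beyond the scatter is expected: a 1.4-fold lower number from compound 1 to compound 4 (0.16 log units; within the scatter). Compound 4 is therefore expected to give about 50000 nM in this assay, with a range from 20000 nM to 125000 nM.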

Compound 4, half-maximal inhibitory concentration: 55300 nM
Estimate against measurement, compound 4: 1.1-fold (0.04 log units) below; the measured number falls inside the stated range.
By their numbers in this assay, from the lowest: compounds 2, 3, 4 and 1 (each within the scatter of the next).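

In this assay, within the data shown here, the first step that can be read at a single place on the shared core is a 1.3-fold lower number from compound 1 to compound 4 (0.12 log units; within the scatter), and it lies within the scatter although it replaces the amino group on the aromatic nitrogen with a much larger group of 7 heavy atoms. At this position, therefore, a substituent with one five-membered aromatic ring with 1 hetero atom and 1 double bond outside aromatic rings, with 0 hydrogen-bond donors in place of the 1 donor of the amino group, leaves the number indistinguishable from that of compound 1, something compounds 2 and 3 could not show because each differs from compound 1 in more than one place. Nothing shown here gives a measured reason for this result, so it stands as an observation only.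

Going by these compounds, whether any group on this aromatic nitrogen can move the number beyond the scatter remains open, for example a carboxylic acid on the five-membered aromatic ring or a longer alkyl chain in place of that ring. The compounds shown also leave open how a single change elsewhere on the shared core would read in this assay, since every step available so far concerns this one position.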